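A few compounds are considered here, and "the series" means these few. Any claim that something is new, unique, unknown or untested is made for them only; others in the source may bear on it.

Compound 2 `CCOc1ccc(C(=O)/C=C/c2ccc(C(=O)Nc3cccc(-c4cc(C(=O)OC)no4)c3)cc2)cc1` stands at a limit of an ADME assay on Vero cells (Chlorocebus sabaeus) for cytotoxicity, read by MTT assay, with a stated time of 72 h (on this read-out lower numbers stand for higher toxicity in this test and higher numbers for lower toxicity in this test), giving > 40 ug/mL. Compound 1 `COC(=O)c1cc(-c2cccc(NC(=O)c3ccc(/C=C/C(=O)c4cc(F)ccc4F)cc3)c2)on1` likewise reaches only a limit, with > 40 ug/mL. Among the compounds with values here, the one measured step, a step that the two limits leave unreadable from compound 1 to compound 2, is therefore unreadable, and the limit of > 40 ug/mL in this assay, at which 2 of the 2 values shown sit, is all that the numbers show. Compound 3 `COC(=O)c1cc(-c2cccc(NC(=O)c3ccc(/C=C/C(=O)c4ccc(Br)cc4)cc3)c2)on1` differs from compound 2 by bromo in place of ethoxy on an aromatic carbon. With no readable step to lean on, compound 3 is expected to remain at the same limit in this assay, an expected step of a number no higher from compound 2 to compound 3 (the limit leaves the size open). The estimate for compound 3 is 40 ug/mL, with a range from 20 ug/mL to 80 ug/mL.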

Compound 3, half-maximal cytotoxic concentration: > 20 ug/mL
Compound 3 ended at the assay's limit (the forecaster's own chance of this, stated with the estimate: 85%); the middle value lies beyond the limit too.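

Within the data shown here, compound 1, compound 2 and compound 3 all stand at limits in this assay, so no step among them can be read. The compounds shown leave open whether 4-bromophenyl, 4-ethoxyphenyl and 2,5-difluorophenyl differ at all in half-maximal cytotoxic concentration.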